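Swapping chloro for tert-butyl on a benzyl-indole urea

This account rests on a few compounds, and the source may have more. Where it says the series, first, only, none or still open, it means among the compounds named here.

Three compounds have so far been measured in a functional assay on A549 cells (Homo sapiens) for cytotoxicity, read by MTT assay, with a stated time of 72 h; a higher number here means a weaker inhibitor, a lower number a stronger inhibitor:

Compound 1 `CCN(CC)Cc1ccc2nc(NC(=O)N/N=C/c3cn(Cc4ccc(C(C)(C)C)cc4)c4ccccc34)sc2c1` gives 1710 nM.
Compound 2 `CCN(CC)Cc1ccc2nc(NC(=O)N/N=C/c3cn(Cc4ccc(Cl)cc4)c4ccccc34)sc2c1` gives 2940 nM.
Compound 3 `CC1CCN(Cc2ccc3nc(NC(=O)N/N=C/c4cn(Cc5ccc(Cl)cc5)c5ccccc45)sc3c2)CC1` gives 2030 nM.

Compound 4 `CC1CCN(Cc2ccc3nc(NC(=O)N/N=C/c4cn(Cc5ccc(C(C)(C)C)cc5)c5ccccc45)sc3c2)CC1` has not yet been measured. It is made from compound 3 by one change, (tert-butyl in place of chloro on an aromatic carbon). All three measured values lie close together, so none of the three can be called stronger or weaker than another.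

The same change has already been made once among the measured compounds, between compound 2 and compound 1: tert-butyl in place of chloro on an aromatic carbon. That step gave a 1.7-fold lower number from compound 2 to compound 1 (0.24 log units; within the scatter), a shift that stays inside the usual scatter of this assay. The two cores on which the change is made differ in one spot: 4-methylpiperidin-1-yl in place of diethylamino on a saturated chain carbon bound to an aromatic carbon. That difference gave a 1.4-fold lower number from compound 2 to compound 3 (0.16 log units; within the scatter), also inside the scatter. The place of the change is described in the same words for both pairs, so the change from compound 3 to compound 4 counts as the same change, not merely the same kind.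

Among the compounds with values here, on this basis the step from compound 3 to compound 4 is expected to be about a 1.6-fold lower number from compound 3 to compound 4 (0.21 log units; within the scatter), resting on the single earlier step of a 1.7-fold lower number from compound 2 to compound 1 (0.24 log units; within the scatter). Compound 4 is accordingly estimated at 1250 nM, with a likely range from 600 nM to 2700 nM; this is an expectation drawn from one prior example and a small set of compounds.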

Compound 4, half-maximal inhibitory concentration: 3710 nM
Beside the measured number, compound 4's estimate is 3.0-fold (0.47 log units) below it, and the stated range ends below it.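

In this assay, putting tert-butyl in place of chloro gives a 1.8-fold higher number from compound 3 to compound 4 (0.26 log units; within the scatter), which is small taken alone but points the opposite way from the same change on the diethylamino core, and the two steps do not agree: the same change on two cores in this assay, a 1.7-fold lower number (0.24 log units; within the scatter) from compound 2 to compound 1 and a 1.8-fold higher number (0.26 log units; within the scatter) from compound 3 to compound 4, 3.1-fold (0.50 log units) apart, beyond the scatter of two such steps

The other side of the same square of four compounds tells the same story, since 4-methylpiperidin-1-yl in place of diethylamino gives a 2.2-fold higher number from compound 1 to compound 4 (0.34 log units; beyond the scatter) with tert-butyl present, and this does not match the step seen with chloro present: the same change on two cores in this assay, a 1.4-fold lower number (0.16 log units; within the scatter) from compound 2 to compound 3 and a 2.2-fold higher number (0.34 log units; beyond the scatter) from compound 1 to compound 4, 3.1-fold (0.50 log units) apart, beyond the scatter of two such steps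

So in these four compounds neither change can be carried from one core to another as a fixed shift, and the effect of each depends on which group sits at the other end of the molecule; this does not show why the two ends interact, nor that the tert-butyl swap by itself moves the number on either core, and it rests on one square of compounds in a single cell assay.

On these data alone, whether the same mismatch appears with other groups in place of chloro, such as methoxy or trifluoromethyl, remains open. So does whether it persists with other amines in place of diethylamino, such as morpholin-4-yl or pyrrolidin-1-yl.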